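Two aryloxypyridine series members and a ring-for-chain replacement

The source may report more compounds than this note shows. Statements on the series, on what has been measured and on what is new or still open speak of the compounds shown alone.

Two compounds carry measurements so far. Compound 1 `Cc1c(F)c(Oc2cccc(C(=N)N)c2)nc(Oc2ccc(Cl)c(N(C)C)c2)c1F` gives 1000 nM in an assay on isolated protein for inhibition of serine protease 1 (Bos taurus); on this read-out higher numbers stand for weaker inhibition and lower numbers for stronger inhibition. Compound 2 `N=C(N)c1cccc(Oc2cc(C(=O)O)cc(Oc3cc(C(=N)N)ccc3O)n2)c1` gives 520 nM in this assay. Compound 2 has the lower of the two numbers, but the gap to compound 1 lies within the scatter of repeated measurements, so no order between them can be claimed.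

Compound 3 `Cc1nccn1-c1cccc(Oc2cc(C(=O)O)cc(Oc3cc(C(=N)N)ccc3O)n2)c1` is not yet measured. It differs from compound 2 in one place: a group of 6 heavy atoms (4 carbon, 2 nitrogen; one five-membered aromatic ring with 2 hetero atoms) in place of a group of 3 heavy atoms (1 carbon, 2 nitrogen; no ring), on an aromatic carbon. Within the data shown here, no pair of measured compounds shows a step of this kind, so the expected direction rests only on the structural change itself. A group with two hydrogen-bond donors leaves and a group with none enters, and the change is expected to weaken inhibition in this assay, with a step from compound 2 to compound 3 of about a 3.1-fold higher number from compound 2 to compound 3 (0.49 log units; beyond the scatter), beyond the scatter though not by a large margin. Compound 3 is therefore estimated at 1600 nM in this assay, with a range from 450 nM to 6000 nM reflecting the absence of any comparable measured step.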

Compound 3, inhibition constant: 580 nM
Beside the measured number, compound 3's estimate is 2.8-fold (0.44 log units) above it; the measured number falls inside the stated range.
By their numbers in this assay, from the lowest: compounds 2, 3 and 1 (each within the scatter of the next).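

In this assay the change at this position gives a 1.1-fold higher number from compound 2 to compound 3 (0.05 log units; within the scatter), so compound 2 and compound 3 cannot be told apart on this read-out. This aromatic carbon, meta to a large group, therefore carries 2-methyl-1H-imidazol-1-yl, with its five-membered aromatic ring and 0 hydrogen-bond donors, in place of the ring-free group of 3 heavy atoms with 2 hydrogen-bond donors, and the read-out does not move beyond the scatter; compound 1 and compound 2 differ in more than one place and could not show this. No measurement on hand gives a reason for this result.

The compounds shown leave open how far this tolerance extends at this position, since a primary amine, a carboxylic acid or a longer chain such as a butyl chain on the same aromatic carbon could read differently from the 2-methyl-1H-imidazol-1-yl group. They also leave open whether the same replacement would be tolerated at the second copy of the ring-free group of 3 heavy atoms, which compound 3 still carries on its other ring.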